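The source may report more compounds than this note shows. Statements on the series, on what has been measured and on what is new or still open speak of the compounds shown alone.

The measured compounds:

Compound 1, `CC(=O)O[C@@H]1OC(n2nc(-c3ccccc3)n(/N=C/c3ccc(O)cc3)c2=S)[C@@H](C(C)=O)[C@H](OC(C)=O)[C@H]1OC(C)=O`: 11300 nM
Compound 2, `CC(=O)OC[C@H]1O[C@@H](n2nc(-c3ccccc3)n(/N=C/c3ccccc3)c2=S)[C@H](OC(C)=O)[C@@H](OC(C)=O)[C@@H]1OC(C)=O`: 10700 nM
Compound 3, `COc1cc(/C=N/n2c(-c3ccccc3)n[nH]c2=S)ccc1O`: 19600 nM

All three numbers come from a functional assay on Bel-7402 cells (Homo sapiens) for antiproliferative activity, read by MTT assay, with a stated time of 24 h; a higher number here means a weaker inhibitor, a lower number a stronger inhibitor. Compound 3 gives the highest of the three numbers, yet it sits within the scatter of both of the others: compound 1 gives a value that is lower by an amount inside the usual variation, and compound 2 likewise. On these figures, then, no order among the three compounds can be claimed, and compound 3 is simply one of three weak inhibitors.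

Compound 4, `Oc1ccc(/C=N/n2c(-c3ccccc3)n[nH]c2=S)cc1`, has not yet been measured in this assay. It differs from compound 3 in one place: hydrogen in place of methoxy on an aromatic carbon. Among the measured compounds shown here, no pair of measured compounds shows this step, so its size is unknown from the data. Given that every measured value lies in the same weak range, the writer expects the step from compound 3 to compound 4 to be small and most likely within the scatter, in either direction, as a 1.2-fold lower number from compound 3 to compound 4 (0.06 log units; within the scatter). Compound 4 is thus estimated at 17000 nM in this assay. The expected range for compound 4 runs from 7000 nM to 42000 nM.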

Compound 4, half-maximal inhibitory concentration: 25200 nM
The estimate for compound 4 lay 1.5-fold (0.17 log units) below the measured number, within the range that was stated.
By their numbers in this assay, from the lowest: compounds 2, 1, 3 and 4 (each within the scatter of the next, the first and the last beyond it).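

Among the compounds shown here, replacing the methoxy with hydrogen on the aromatic carbon, ortho to a hydroxy group and meta to a large group, gives in this assay a 1.3-fold higher number from compound 3 to compound 4 (0.11 log units; within the scatter), the first step in this set that can be read at a single place. It shows that this position can lose the methoxy, with its 2 heavy atoms and its hydrogen-bond acceptor, without any difference that stands clear of the usual variation, so the methoxy is not needed to hold the number in this weak range, and neither compound can be placed ahead of the other. Nothing available speaks to why the two compounds give such similar numbers.

As far as these compounds go, only hydrogen and methoxy are compared at this carbon, so it remains open whether a larger or differently built group there, such as an ethoxy, a chlorine, an amine or a carboxylic acid, would move the number beyond the scatter. The hydroxy group is never changed on its own, and compound 1 and compound 2 differ from compound 3 and compound 4 in more than one place, so the steps to them cannot be read.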